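Unbound fraction notes: from compound 2 to compound 3

The compounds below may be only part of what the source reports. "The series", "measured", "known", "first", "only" and "open" are said of these compounds alone.

compound 1 `Cc1noc(-c2ccc(O[C@H]3CCC[C@H](C(=O)O)C3)cc2)c1CNC(=O)OCCC(C)(C)C`: 0.001
compound 2 `Cc1noc(-c2ccc(O[C@H]3CCC[C@H](C(=O)O)C3)cc2)c1CNC(=O)OCc1ccccc1`: 0.004

In an ADME assay on the whole organism (plasma, Rattus norvegicus, strain Sprague-Dawley) for protein binding, read by LC-MS, with a stated time of 24 h (on this read-out higher numbers stand for a larger free fraction and lower numbers for a smaller free fraction), compound 2 gives 0.004 as the higher of the two numbers, with compound 1 lower. Here compound 3 `Cc1noc(-c2ccc(O[C@H]3CCC[C@H](C(=O)O)C3)cc2)c1COC(=O)N(C)C1CCCC1` remains unmeasured. The change is a group of 10 heavy atoms (7 carbon, 1 nitrogen, 2 oxygen; one five-membered non-aromatic ring of carbon only) in place of a group of 11 heavy atoms (8 carbon, 1 nitrogen, 2 oxygen; one six-membered aromatic ring of carbon only), on a saturated chain carbon bound to an aromatic carbon and it sits on a saturated chain carbon bound to an aromatic carbon, where the (benzyloxycarbonyl)amino group leaves. Among the measured compounds shown here, only one measured step bears on this, the modest 4.0-fold higher number from compound 1 to compound 2 (0.60 log units; beyond the scatter) when phenyl replaced neopentyl. For the measured compounds named here, with that step as the sole guide, a small move to a lower number in this assay is expected, as compound 3 also lacks a six-membered aromatic ring of carbon only. One step is thin support, and the groups involved differ. The expected size is a 1.6-fold lower number from compound 2 to compound 3 (0.20 log units; within the scatter) and no more. For compound 3 the estimated value is 0.0025 with an expected range of 0.001 to 0.006 in this read-out.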

Compound 3, unbound fraction: 0.002
The estimate for compound 3 lay 1.3-fold (0.10 log units) above the measured number; the measured number falls inside the stated range.
By their numbers in this assay, from the lowest: compounds 1, 3 and 2 (each within the scatter of the next, the first and the last beyond it).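

Read in this assay the steps of a 2.0-fold lower number from compound 2 to compound 3 (0.30 log units; within the scatter) and a 2.0-fold higher number from compound 1 to compound 3 (0.30 log units; within the scatter) both stay within the scatter, so on a saturated chain carbon bound to an aromatic carbon this group, with one five-membered non-aromatic ring of carbon only and 0 hydrogen-bond donors, gives no step beyond the scatter from either neighbour. Among the three compounds, a six-membered aromatic ring of carbon only is therefore not required for a number within the scatter of compound 2. No measurement among these compounds accounts for the numbers.

The entering group differs from (benzyloxycarbonyl)amino in more than its ring, and the compounds shown do not separate those parts. Going by these compounds, how an amine, a morpholine ring or a longer chain ending in a hydroxyl group would read at this place remains open.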